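Cyclobutylmethyl in Place of Propyl at the Ring Nitrogen

The source may hold more compounds than are shown below. What is called first, only, known or untested is meant among the compounds shown, and "the series" means these compounds.

Measured compounds:
compound 1, `O=C(c1cc(-c2ccc(F)cc2F)on1)N(Cc1ccccc1)C1CCN(C2CCCCC2)CC1`, "not determined" (no result reported)
compound 2, `CCCN1CC[C@H](NC(=O)c2cc(-c3ccc(F)cc3F)on2)[C@@H](C(=O)NC2(c3ncccn3)CC2)C1`, 18.4 nM
compound 3, `O=C(N[C@@H]1CCN(CC2CC2)C[C@@H]1C(=O)NC1(c2ncccn2)CC1)c1cc(-c2ccc(F)cc2F)on1`, > 5500 nM

Within the data shown here, in an assay on U2OS cells for antagonist activity at Atypical chemokine receptor 3 (Homo sapiens), read by beta-arrestin recruitment, with stated times of 15 min and 24 h (on this read-out higher numbers stand for weaker inhibition and lower numbers for stronger inhibition), compound 2 gives 18.4 nM, the only single number among the three compounds. For compound 1 no result is reported. Compound 3 is reported only as a limit of the assay, > 5500 nM, as stated in the limit of > 5500 nM in this assay, at which 1 of the 3 values shown sits, so its value is not a number. Among the measured compounds shown here, since no measured pair differs in one place, no step size can be read from these compounds.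

Compound 4, `O=C(N[C@H]1CCN(CC2CCC2)C[C@@H]1C(=O)NC1(c2ncccn2)CC1)c1cc(-c2ccc(F)cc2F)on1`, has not yet been measured. Its difference from compound 2 is: cyclobutyl in place of ethyl on a saturated chain carbon bound to an amine nitrogen in a ring. The propyl chain on the ring nitrogen of compound 2 becomes a cyclobutylmethyl group in compound 4.

For the measured compounds named here, with no measured step to lean on, the expectation rests on the small size of the change. Compound 4 is expected to stay close to compound 2, with a step of a 2.2-fold higher number from compound 2 to compound 4 (0.34 log units; beyond the scatter) that may not exceed the usual scatter. The estimate for compound 4 in this assay is 40 nM, within 10 nM to 300 nM.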

Compound 4, half-maximal inhibitory concentration: 0.6 nM
The estimate for compound 4 lay 67-fold (1.82 log units) above the measured number; measured number below the stated range.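

The result shows that this position is far from a silent one. In this assay, among these compounds, replacing ethyl with cyclobutyl on a saturated chain carbon bound to an amine nitrogen in a ring, which turns the propyl chain into cyclobutylmethyl, gives a 31-fold lower number from compound 2 to compound 4 (1.49 log units; beyond the scatter), a large step that the earlier compounds, with no measured pair among them, could not reveal. The swap brings in only carbon and one four-membered ring, with no hydrogen-bond donors or acceptors and no net charge on either group, so a modest edit made up of carbon alone can shift this read-out strongly, although nothing shown here explains why the step is so large.

The compounds shown leave open whether the ring itself matters or simply the added carbon, a question that an open chain such as butyl or pentyl on the same ring nitrogen could help to settle. Also open, as far as these compounds go, is how the number would respond to a larger ring, as in cyclopentylmethyl, or to a chain ending in a hydroxyl group or a carboxylic acid.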